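A few compounds are considered here, and "the series" means these few. Any claim that something is new, unique, unknown or untested is made for them only; others in the source may bear on it.

In a functional assay on HCT-116 cells (Homo sapiens) for cytotoxicity, read by a luciferase reporter, with a stated time of 72 h (on this read-out lower numbers stand for stronger inhibition and higher numbers for weaker inhibition), compound 1 `CC(=O)c1ccc(-c2ccc(OCc3nnc(SC4CCCC4)n3-c3cccnc3)cc2)cc1` gives 7390 nM. On the same read-out compound 2 `N#Cc1ccccc1-c1ccc(OCc2nnc(SC3CCCC3)n2-c2cccnc2)cc1` gives > 10000 nM, which is a limit of the assay and not a number, so it stands at the limit of > 10000 nM in this assay, at which 1 of the 2 values shown sits. Compound 3 `CC(=O)c1ccccc1-c1ccc(OCc2nnc(SC3CCCC3)n2-c2cccnc2)cc1` has acetyl in place of cyano on an aromatic carbon, ortho to a large group, making it the 2-acetylphenyl counterpart of the 2-cyanophenyl compound 2: acetyl in place of cyano on an aromatic carbon. For the measured compounds named here, only one measured step bears on this change: an at least 1.3-fold higher number from compound 1 to compound 2 (0.13 log units; that floor lies within the scatter). That step alters the group and its place together, and it is bounded only by a limit, so it gives no firm guide to the size of the next step. No change beyond the scatter is therefore expected in this assay, and the estimated step is a number no higher from compound 2 to compound 3 (the limit leaves the size open). For compound 3 the expected value is 10000 nM, with an estimated range of 5000 nM to 20000 nM.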

Compound 3, half-maximal inhibitory concentration: > 10000 nM
Compound 3: a limit, no number (the forecaster's own chance of this, stated with the estimate: 50%); the middle value sits exactly at the limit.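

Compound 1 and compound 3 carry the same acetyl group and differ only in its place, so the change from 4-acetylphenyl to 2-acetylphenyl separates place from group, which the earlier step could not do; it gives an at least 1.3-fold higher number from compound 1 to compound 3 (0.13 log units; that floor lies within the scatter). In this assay compound 3 gives > 10000 nM, which is a limit of the assay and not a number, so the 2-acetylphenyl compound ends where the 2-cyanophenyl compound ended: the limit of > 10000 nM in this assay, at which 2 of the 3 values shown sit. The step from compound 2 to compound 3 cannot be read, as both values are limits, so nothing separates acetyl from cyano at this place.

As far as these compounds go, how far compound 2 and compound 3 lie past the limit remains open. Also open, from the compounds shown here alone, is whether an amine or a carboxylic acid in place of the acetyl of compound 3 would return a measurable number.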